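A few compounds are considered here, and "the series" means these few. Any claim that something is new, unique, unknown or untested is made for them only; others in the source may bear on it.

Measured compounds in a functional assay on HEK293 cells for agonist activity at Bile acid receptor (Homo sapiens); a higher number here means that more compound is needed for the effect, a lower number that less compound is needed:
Compound 1 `CN(Cc1cccc(C(=O)O)c1)c1ccc(OCc2c(-c3c(Cl)cccc3Cl)noc2C2CC2)nc1C(F)(F)F` gives 9 nM.
Compound 2 `CN(Cc1ccc(C(=O)O)cc1)c1ccc(OCc2c(-c3c(Cl)cccc3Cl)noc2C2CC2)nc1C(F)(F)F` gives 30 nM.
Compound 3 `CC(Nc1ccc(C(=O)O)cc1)c1ccc(OCc2c(-c3c(Cl)cccc3Cl)noc2C2CC2)nc1C(F)(F)F` gives 333 nM.

Compound 3 stands at the highest number of the three, and both gaps lie beyond the scatter: a 37-fold higher number from compound 1 to compound 3 (1.57 log units; beyond the scatter) and an 11-fold higher number from compound 2 to compound 3 (1.05 log units; beyond the scatter). More of compound 3 is therefore needed than of either other compound. Compound 4 `O=C(O)c1ccccc1OCc1ccc(OCc2c(-c3c(Cl)cccc3Cl)noc2C2CC2)nc1C(F)(F)F` has not yet been measured. It differs from compound 3 in one place: (2-carboxyphenoxy)methyl in place of 1-((4-carboxyphenyl)amino)ethyl on an aromatic carbon.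

Among the compounds with values here, no measured step makes exactly this exchange, so the bearing evidence is indirect. Compounds 1 and 2 each carry a carboxyphenyl unit joined through a methyl-bearing nitrogen, and each sits far below compound 3, as the two large steps above show. Where the carboxylic acid sits on its ring mattered less: a 3.3-fold higher number from compound 1 to compound 2 (0.52 log units; beyond the scatter). Exchanging the 1-((4-carboxyphenyl)amino)ethyl group of compound 3 for a (2-carboxyphenoxy)methyl group is expected to bring the number back toward those seen for the other two compounds, so a lower number is expected for compound 4, by a 5.6-fold lower number from compound 3 to compound 4 (0.74 log units; beyond the scatter). The estimate for compound 4 is 60 nM, with a range from 10 nM to 400 nM.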

Compound 4, half-maximal effective concentration: 1710 nM
Beside the measured number, compound 4's estimate is 29-fold (1.45 log units) below it; the whole stated range lies below it.
By their numbers in this assay, from the lowest: compound 1; then compound 2; then compound 3; then compound 4.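

Within the data shown here, at the carbon ortho to the trifluoromethyl group, the earlier compounds showed only that changing the linked group could raise the number. In this assay, the (2-carboxyphenoxy)methyl group gives a 5.1-fold higher number from compound 3 to compound 4 (0.71 log units; beyond the scatter), so this exchange does not recover the lower numbers of the two nitrogen-linked benzyl compounds. The larger gaps, a 57-fold higher number from compound 2 to compound 4 (1.76 log units; beyond the scatter) and a 190-fold higher number from compound 1 to compound 4 (2.28 log units; beyond the scatter), show that a carboxyphenyl unit at this position does not by itself keep the number low, and no measurement here explains the rise.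

This exchange alters the linking atoms and the place of the carboxylic acid together, so the effect of each remains unseparated. A (4-carboxyphenoxy)methyl group, with its carboxylic acid placed as in compound 3, could show whether the oxygen link alone accompanies a higher number.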